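A Thiourea Swap: Phenethyl Out, Chlorophenoxy In

This account rests on a few compounds, and the source may have more. Where it says the series, first, only, none or still open, it means among the compounds named here.

Three thioureas sharing one core have been tested in an ADME assay on Ava5 cells (Homo sapiens) for cytotoxicity; on this read-out higher numbers stand for lower toxicity in this test and lower numbers for higher toxicity in this test. Compound 1 `NC(=S)Nc1cccc(OCc2ccccc2)c1` gives in this assay > 50000 nM, which is a limit of the assay rather than a number, namely (the limit of > 50000 nM in this assay, at which 1 of the 3 values shown sits). Compound 2 `NC(=S)Nc1cccc(OCCCCCCCc2ccccc2)c1` gives 23000 nM in this assay and so stands lowest of the two plain numbers shown, while compound 3 `S=C(Nc1ccccc1)Nc1cccc(OCCCCCc2ccccc2)c1` gives 35000 nM, a gap that falls within the usual scatter of such measurements. Compound 4 `NC(=S)Nc1cccc(OCCCCCOc2ccc(Cl)cc2)c1` has not yet been measured. It differs from compound 2 in one place: 4-chlorophenoxy in place of phenethyl on a saturated chain carbon, five bonds along the chain from an oxygen on an aromatic ring. No measured pair shows this exact change, so its size is open; compounds 2 and 3 differ in several places and still sit within scatter of each other, which gives little reason to expect a large move in the half-maximal cytotoxic concentration. The expected step from compound 2 to compound 4 is therefore a 1.3-fold higher number from compound 2 to compound 4 (0.12 log units; within the scatter), none beyond the scatter. Compound 4 is estimated at 30000 nM, within a range from 12000 nM to 75000 nM.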

Compound 4, half-maximal cytotoxic concentration: 7000 nM
The estimate for compound 4 lay 4.3-fold (0.63 log units) above the measured number, outside the stated range (below it).
By their numbers in this assay, from the lowest: compound 4; then compounds 2 and 3 (each within the scatter of the next). At a limit, above all of these: compound 1.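

In this assay, placing 4-chlorophenoxy in place of phenethyl on a saturated chain carbon, five bonds along the chain from an oxygen on an aromatic ring, gives a 3.3-fold lower number from compound 2 to compound 4 (0.52 log units; beyond the scatter), and a lower number here stands for higher toxicity in this test. Within the data shown here, this is the first single-place change available to read, and it shows that the far end of the chain can matter, even though both groups have the same count of heavy atoms and one six-membered aromatic ring of carbon only. Nothing given here explains the step.

Which of the entering atoms goes with the step, the oxygen or the chlorine, stays open. Plain phenoxy or an amine on the same chain carbon would be the next groups to compare in this test.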